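The source may hold more compounds than are shown below. What is called first, only, known or untested is meant among the compounds shown, and "the series" means these compounds.

Measured so far in a functional assay on MDA-MB-435 cells (Homo sapiens) for antiproliferative activity, read by sulforhodamine B assay, with a stated time of 72 h; a lower number here means a stronger inhibitor, a higher number a weaker inhibitor:
- compound 1 `C(=C/c1ccccc1)\C(=N\Nc1nncc2ccccc12)c1ccccc1` gives 3 nM
- compound 2 `O=S(=O)(Nc1ncccn1)c1ccc(Nc2nncc3ccccc23)cc1` gives 45 nM

Compound 2, at 45 nM, has the higher of the two numbers, which makes it the weaker inhibitor of the pair. Compound 1, at 3 nM, lies lower by clearly more than the usual scatter of repeated measurements. These two differ in more than one place, so their gap says nothing about any single group.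

The next compound, compound 3 `Cc1cc(NS(=O)(=O)c2ccc(Nc3nncc4ccccc34)cc2)no1`, differs from compound 2 in one place: 5-methyl-1,2-oxazol-3-yl in place of pyrimidin-2-yl on a sulfonamide nitrogen. A six-membered aromatic ring thus gives way to a five-membered one. Among the measured compounds shown here, no measured pair shows what such a swap does, so the expectation rests on compound 2 alone, at 45 nM, and no direction can be favoured. In this assay no step beyond the scatter is expected. The expected step is a 1.1-fold higher number from compound 2 to compound 3 (0.05 log units; within the scatter) in size. For compound 3 the estimated value is 50 nM, with an expected range from 15 nM to 170 nM.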

Compound 3, half-maximal inhibitory concentration: 27 nM
The estimate for compound 3 lay 1.9-fold (0.27 log units) above the measured number; measured number inside the range.
By their numbers in this assay, from the lowest: compound 1; then compounds 3 and 2 (each within the scatter of the next).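

In this assay, putting 5-methyl-1,2-oxazol-3-yl in place of pyrimidin-2-yl on a sulfonamide nitrogen gives a 1.7-fold lower number from compound 2 to compound 3 (0.22 log units; within the scatter), so this pair cannot be told apart in this read-out. Among the compounds shown here, this is the first measured pair that differs in one place, and it shows that at this position a six-membered aromatic ring can give way to a five-membered one, with a different set of ring atoms and an added methyl group, without a step beyond the usual scatter. No measurement here offers a reason for this result, and the similar numbers alone cannot supply one.

For the compounds shown here, one pair covers only two closely matched groups, each with the same counts of heavy atoms, hydrogen-bond donors and hydrogen-bond acceptors, so it cannot show how far this position would accept something quite different, such as a plain phenyl ring, a carboxylic acid, an amine or a longer alkyl chain. The compounds shown also leave open what the sulfonamide itself contributes, since no pair here changes that link alone.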